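A few compounds are considered here, and "the series" means these few. Any claim that something is new, unique, unknown or untested is made for them only; others in the source may bear on it.

Measured so far:
compound 1, `CCc1nc(C(C)C)c2n1CCN([C@@H](C(=O)NC)c1ccccc1)C2CCc1ccc(C(F)(F)F)cc1` — 10000 nM
compound 2, `CCc1nc(C)c2n1CCN([C@@H](C(=O)NC)c1ccccc1)C2CCc1ccc(C(F)(F)F)cc1` — 10000 nM
compound 3, `CNC(=O)[C@@H](c1ccccc1)N1CCn2c(C(C)C)nc(Cl)c2[C@@H]1CCc1ccc(C(F)(F)F)cc1` — 313 nM

In a functional assay on CHO cells for antagonist activity at Orexin/Hypocretin receptor type 1 (Homo sapiens), read by FLIPR and calcium flux (a lower number here means a stronger inhibitor, a higher number a weaker inhibitor), compound 1 gives 10000 nM and compound 2 gives 10000 nM; the two are within the scatter of each other. The change between them, (methyl in place of isopropyl on an aromatic carbon), made the step of no change at the digits printed from compound 1 to compound 2 (within the scatter). Compound 3 stands apart: in this assay compound 3 gives 313 nM, the lowest of the three numbers, a step beyond the scatter from both compound 1 and compound 2. The difference between the core of compound 3 and the core of compound 1 is not broken down here.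

Compound 4, `CNC(=O)[C@@H](c1ccccc1)N1CCn2c(C)nc(Cl)c2[C@@H]1CCc1ccc(C(F)(F)F)cc1`, has not yet been measured in this assay. It differs from compound 3 by methyl in place of isopropyl on an aromatic carbon. For the measured compounds named here, this is the same kind of change as the one from compound 1 to compound 2, but not the same: in compound 1 the carbon that loses the isopropyl is next to the ring nitrogen and two ring bonds from the ring atom that bears an ethyl group, whereas in compound 3 it lies between two ring nitrogen atoms and two ring bonds from the ring atom that bears a chloro group.

Because no change at the digits printed from compound 1 to compound 2 (within the scatter) was flat, the account expects a similar outcome here, with the step of a 1.3-fold higher number from compound 3 to compound 4 (0.11 log units; within the scatter) expected from compound 3 to compound 4. This rests on a single pair, so the expectation is held loosely. For compound 4 in this assay the estimate is 400 nM, expected to fall between 150 nM and 1200 nM.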

Compound 4, half-maximal inhibitory concentration: 90 nM
For compound 4 the middle estimate is 4.4-fold (0.65 log units) above the measured one; measured number outside the range, below it.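

In this assay, methyl in place of isopropyl on an aromatic carbon gave a clear gain on the core of compound 3 (a 3.5-fold lower number from compound 3 to compound 4 (0.54 log units; beyond the scatter)), whereas the same swap on the core of compound 1 gave no change at the digits printed from compound 1 to compound 2 (within the scatter), so the change did not carry over unaltered from one core to the other: the same change on two cores in this assay, no change at the digits printed (within the scatter) from compound 1 to compound 2 and a 3.5-fold lower number (0.54 log units; beyond the scatter) from compound 3 to compound 4, 3.5-fold (0.54 log units) apart, beyond the scatter of two such steps.

The result shows that the outcome of this swap on one core is a poor guide to its outcome on the other in this series, even though the group leaving and the group entering are the same. It does not show which difference between the two cores separates the steps, nor does it set a general rule, since it rests on only these two pairs.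

The compounds shown leave open whether the trend on the core of compound 3 continues with a hydrogen or a cyclopropyl group on that carbon, or whether the same step would appear if the chloro group gave way to a bromo group or a nitrile. They also leave open whether the swap would behave in the same way on any further core in this assay.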